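The source may report more compounds than this note shows. Statements on the series, on what has been measured and on what is new or still open speak of the compounds shown alone.

Measured compounds:
compound 1 `O=C1Nc2ccccc2/C1=C1/Cc2ccccc2C1=O`, > 100000 nM
compound 2 `O=C1Nc2ccc(Br)cc2/C1=C1/Cc2ccccc2C1=O`, > 100000 nM
compound 3 `O=C1NC(=S)N/C1=C1\C(=O)Nc2ccccc21`, 75500 nM

In a functional assay on PC-3 cells (Homo sapiens) for antiproliferative activity, read by MTT assay, with a stated time of 72 h (on this read-out higher numbers stand for weaker inhibition and lower numbers for stronger inhibition), compound 1 gives > 100000 nM, which is a limit of the assay and not a number. Compound 2 likewise gives only a limit, > 100000 nM. The change from compound 1 to compound 2 is bromo in place of hydrogen on an aromatic carbon, and the step it made is a step that the two limits leave unreadable from compound 1 to compound 2 because of the limit of > 100000 nM in this assay, at which 2 of the 3 values shown sit. Compound 3 carries a different core; the difference between the two cores is not broken down here. In this assay, going by the values given here, compound 3 gives 75500 nM, the only number among the three.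

Compound 4 `O=C1NC(=S)N/C1=C1\C(=O)Nc2c(Br)cccc21` is not yet measured. It differs from compound 3 by bromo in place of hydrogen on an aromatic carbon. Among the compounds with values here, this is the same kind of change as the one from compound 1 to compound 2, but the place differs: in compound 2 the bromo sits meta to a fused ring and para to a fused ring, whereas in compound 4 it sits ortho to a fused ring and meta to a fused ring. Since the earlier step sits between two limits, its size is not readable, so no measured direction is available for the change. The expectation for compound 4 is therefore built on compound 3 alone: the step from compound 3 to compound 4 is expected to be a 1.2-fold lower number from compound 3 to compound 4 (0.07 log units; within the scatter), within the usual scatter, in this assay. On that basis compound 4 is estimated at 65000 nM, expected to lie between 20000 nM and 200000 nM, with a real chance that only a limit is reported.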

Compound 4, half-maximal inhibitory concentration: 22800 nM
Compound 4: the middle estimate sits 2.9-fold (0.45 log units) above what was measured; measured number inside the range.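

In this assay, bromo in place of hydrogen on an aromatic carbon gives a 3.3-fold lower number from compound 3 to compound 4 (0.52 log units; beyond the scatter), a modest gain in inhibition on the core shared by that pair. Compound 1 and compound 2 each give only a limit and not a number, so the same change on their core cannot be read, and no comparison of its size or direction between the two cores is possible: the limit of > 100000 nM in this assay, at which 2 of the 4 values shown sit. The bromo of compound 4 also sits ortho to a fused ring and meta to a fused ring, while that of compound 2 sits at another place, so this one readable step shows an effect on one core at one place and gives no rule that carries from core to core.

As far as these compounds go, it remains open whether the gain is specific to bromo or would also appear with chloro, methoxy or an amine at the same place on the core of compound 3. Also open, from the compounds shown here alone, is whether bromo at the other aromatic carbons of that ring would give a step of similar size, or whether a step on the core of compound 1 could be read at all.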